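This account rests on a few compounds, and the source may have more. Where it says the series, first, only, none or still open, it means among the compounds named here.

Values measured in a functional assay, read by spectrophotometry, tested at 100 uM; on this read-out lower numbers stand for stronger inhibition and higher numbers for weaker inhibition:

- compound 1 `O=C(/C=C/c1cccs1)c1cccc(NC(=O)c2cc(-c3ccncc3)n[nH]2)c1` gives 27600 nM
- compound 2 `CN(C)c1ccc(/C=C/C(=O)c2cccc(NC(=O)c3cc(-c4ccncc4)n[nH]3)c2)cc1` gives 41900 nM
- compound 3 `O=C(/C=C/c1ccccc1Cl)c1cccc(NC(=O)c2cc(-c3ccncc3)n[nH]2)c1` gives 27700 nM

These three compounds share a core and differ only in the group on the double-bonded chain carbon. Compound 1 cannot be separated from the other two, since both steps away from it stay within the scatter: a 1.5-fold higher number from compound 1 to compound 2 (0.18 log units; within the scatter) and a 1.0-fold higher number from compound 1 to compound 3 (0.00 log units; within the scatter). The remaining pair gives the same picture, with a 1.5-fold lower number from compound 2 to compound 3 (0.18 log units; within the scatter).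

The next compound is compound 4 `O=C(/C=C/c1ccc(Cl)cc1Cl)c1cccc(NC(=O)c2cc(-c3ccncc3)n[nH]2)c1`, which differs from compound 1 as follows: 2,4-dichlorophenyl in place of thiophen-2-yl on a double-bonded chain carbon bound to a double-bonded chain carbon. Within the data shown here, the closest precedent is compound 3, whose 2-chlorophenyl stands at the same place and whose step from compound 1 was a 1.0-fold higher number from compound 1 to compound 3 (0.00 log units; within the scatter). Even the change to 4-(dimethylamino)phenyl in compound 2 stayed within the scatter. No step beyond the scatter is therefore expected in this assay, and no direction can be called. The expected result is a 1.0-fold higher number from compound 1 to compound 4 (0.01 log units; within the scatter). For compound 4 the estimated value is 28000 nM, with an expected range from 15000 nM to 52000 nM.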

Compound 4, half-maximal inhibitory concentration: 35000 nM
Beside the measured number, compound 4's estimate is 1.3-fold (0.10 log units) below it; low and high end bracket the measured number.
By their numbers in this assay, from the lowest: compounds 1, 3, 4 and 2 (each within the scatter of the next).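

In this assay, the place on a double-bonded chain carbon bound to a double-bonded chain carbon also accepts 2,4-dichlorophenyl without a step beyond the scatter (a 1.3-fold higher number from compound 1 to compound 4 (0.10 log units; within the scatter)). Among these compounds, the result adds a comparison that the earlier compounds did not offer, chloro in place of hydrogen on an aromatic carbon, and this too stays within the scatter (a 1.3-fold higher number from compound 3 to compound 4 (0.10 log units; within the scatter)), as does the comparison with the 4-(dimethylamino)phenyl compound (a 1.2-fold lower number from compound 2 to compound 4 (0.08 log units; within the scatter)). No measurement is available that would account for these small steps.

On these data alone, all four compounds carry an aromatic ring at this place, so it remains open whether a cyclohexyl group, a carboxylic acid or a longer chain ending in an amine would move the number beyond the scatter. Also open, as far as these compounds go, is what replacing the double-bonded chain itself with a saturated chain would do.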